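The compounds below may be only part of what the source reports. "The series", "measured", "known", "first", "only" and "open" are said of these compounds alone.

Notes on the series around compound 1 `Cc1c(O)ccc2c1[C@H](Cn1cc(-c3ccccc3)nn1)[C@@]13CC(=O)[C@@](C)(CC[C@@H]21)C3`. In a functional assay on HL-60 cells (Homo sapiens) for cytotoxicity, read by MTT assay, with a stated time of 4 days (a higher number here means a weaker inhibitor, a lower number a stronger inhibitor), compound 1 gives > 20000 nM, which is a limit of the assay and not a number. Compound 3 `Cc1ccc(S(=O)(=O)Oc2ccc3c(c2C)[C@H](Cn2cc(-c4ccccc4)nn2)[C@@]24CC(=O)[C@@](C)(CC[C@@H]32)C4)cc1` carries a (4-methylphenyl)sulfonyl in place of hydrogen on an oxygen on an aromatic ring; in this assay compound 3 gives > 20000 nM, again a limit. The step that the two limits leave unreadable from compound 1 to compound 3 therefore cannot be read. Compound 2 `C=C1C(=O)[C@]23C[C@@]1(O)CC[C@H]2c1ccc(OS(=O)(=O)c2ccc(C)cc2)c(C)c1[C@@H]3Cn1cc(-c2ccccn2)nn1`, which differs from the others in several places at once, gives 1810 nM in this assay and is the only one of the three with a measured number.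

Compound 4 `Cc1c(O)ccc2c1[C@H](Cn1cc(-c3ccc(F)cc3)nn1)[C@@]13CC(=O)[C@@](C)(CC[C@@H]21)C3` differs from compound 1 by fluoro in place of hydrogen on an aromatic carbon. For the measured compounds named here, no measured step involves this change, and the single recorded step is unreadable because both of its values sit at the limit of > 20000 nM in this assay, at which 2 of the 3 values shown sit. Compound 4 is expected to stay near that limit, an expected step that the limit leaves unreadable from compound 1 to compound 4. The estimate for compound 4 in this assay is 25000 nM, within 8000 nM to 80000 nM, most probably reported again only as a limit.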

Compound 4, half-maximal inhibitory concentration: > 20000 nM
Compound 4: a limit, no number; the forecaster's own chance of this, stated with the estimate: 80%; the middle value lies beyond the limit too.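

In this assay compound 4 gives > 20000 nM, a limit and not a number. For the compounds shown here, compound 1 also sits at a limit, and no step between compound 1 and compound 4 can be read. The compounds shown leave open what fluoro in place of hydrogen on an aromatic carbon does to potency in this series.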